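A few compounds are considered here, and "the series" means these few. Any claim that something is new, unique, unknown or untested is made for them only; others in the source may bear on it.

Compound 2 `COc1ccc2[nH]c(C(=O)N3CC(=O)N(Cc4ccccc4)[C@@H](COC(C)(C)C)C3)cc2c1` gives the highest solubility of the two compounds measured in a physicochemical assay for solubility, read by spectrophotometry, in phosphate buffer, with a stated time of 2 h, at pH 7.4 (on this read-out higher numbers stand for higher solubility and lower numbers for lower solubility), namely 65500 nM. Within the data shown here, its nearest neighbour, compound 1 `COc1cccc(CN2C(=O)CN(C(=O)c3cc4cc(OC)ccc4[nH]3)C[C@@H]2CC2CCCCC2)c1`, gives in this assay a value of 21400 nM, a gap that lies beyond the scatter of repeated measurements, though no single-point step links these two structures.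

Compound 3 `COc1ccc2[nH]c(C(=O)N3CC(=O)N(Cc4ccccc4)[C@@H](CN4CC5CCCC5C4)C3)cc2c1` has not yet been measured in this assay. It differs from compound 2 in one place: a group of 8 heavy atoms (7 carbon, 1 nitrogen; one five-membered non-aromatic ring of carbon only, one five-membered non-aromatic ring with 1 hetero atom) in place of a group of 5 heavy atoms (4 carbon, 1 oxygen; no ring), on a saturated chain carbon bound to a saturated ring carbon. Among the measured compounds shown here, no measured pair shows this change, so its effect can only be expected, not read off. The account expects the change to raise solubility, with the step of a 2.4-fold higher number from compound 2 to compound 3 (0.39 log units; beyond the scatter) estimated to carry compound 3 clearly above compound 2, beyond the scatter. On that basis compound 3 is expected to give 160000 nM in this assay. The estimated range for compound 3 runs from 50000 nM to 450000 nM.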

Compound 3, solubility: 20700 nM
Compound 3: middle estimate off by 7.7-fold (0.89 log units), on the high side, and the stated range ends above it.
By their numbers in this assay, from the lowest: compounds 3 and 1 (each within the scatter of the next); then compound 2.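

Among these compounds, at this place, on a saturated chain carbon bound to a saturated ring carbon, the new pair gives the first direct reading of a single change in this assay: the group with one five-membered non-aromatic ring of carbon only and one five-membered non-aromatic ring with 1 hetero atom, in place of tert-butoxy, gives a 3.2-fold lower number from compound 2 to compound 3 (0.50 log units; beyond the scatter) and so lowers solubility. The earlier compounds shown here offered no such pair, and this one pair sets a direction for this change alone, not a rule for the position. No measurement at hand accounts for the fall.

The compounds shown leave open how a dimethylamino group, a carboxylic acid or a longer alkyl chain at this place would read in this assay. They also leave open whether the same exchange would give a step of similar size on another core.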